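This account rests on a few compounds, and the source may have more. Where it says the series, first, only, none or still open, it means among the compounds named here.

In a functional assay (aorta) with Rattus norvegicus as the target (a lower number here means a stronger inhibitor, a higher number a weaker inhibitor), compound 1 `CCCCc1cn2ccccc2c1S(=O)(=O)c1ccc(OCCCN(CCCC)CCCC)cc1` gives 284 nM, compound 2 `CCCCN(CCCC)CCCOc1ccc(S(=O)(=O)c2c(C(C)C)cn3ccccc23)cc1` gives 21.6 nM, and compound 3 `CCCCN(CCCC)CCCOc1ccc(S(=O)(=O)c2c(C3CCCCC3)cn3ccccc23)cc1` gives 4070 nM, the highest of the three numbers. Compound 4 `CCCCN(CCCC)CCCOc1ccc(S(=O)(=O)c2c(CCC)cn3ccccc23)cc1` is still unmeasured and differs from compound 3 by one change: propyl in place of cyclohexyl on an aromatic carbon. Going by the values given here, two measured steps bear on it, and both are large: a 14-fold higher number from compound 1 to compound 3 (1.16 log units; beyond the scatter) and a 190-fold higher number from compound 2 to compound 3 (2.28 log units; beyond the scatter). Each replaces an open-chain group, butyl or isopropyl, with cyclohexyl. Going the other way, from cyclohexyl to propyl, a large drop in the number is therefore expected in this assay. The expected step is a 45-fold lower number from compound 3 to compound 4 (1.66 log units; beyond the scatter). Compound 4 is estimated at 90 nM, with an expected range from 20 nM to 400 nM.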

Compound 4, half-maximal inhibitory concentration: 54.3 nM
For compound 4 the middle estimate is 1.7-fold (0.22 log units) above the measured one; low and high end bracket the measured number.
By their numbers in this assay, from the lowest: compound 2; then compound 4; then compound 1; then compound 3.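

On this aromatic carbon of the five-membered ring, in this assay, propyl restores most of what cyclohexyl loses (a 75-fold lower number from compound 3 to compound 4 (1.87 log units; beyond the scatter)). The open chains also separate from each other by smaller steps beyond the scatter: isopropyl is ahead of propyl (a 2.5-fold higher number from compound 2 to compound 4 (0.40 log units; beyond the scatter)), and shortening butyl to propyl lowers the number (a 5.2-fold lower number from compound 1 to compound 4 (0.72 log units; beyond the scatter)). No measurement explains this ranking. On these data alone, whether ethyl or methyl would continue the trend at this position remains open, as does the effect of a chain ending in a hydroxyl or an amine.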